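A few compounds are considered here, and "the series" means these few. Any claim that something is new, unique, unknown or untested is made for them only; others in the source may bear on it.

Measured in an ADME assay on microsomes from liver (Homo sapiens) for metabolic stability; a higher number here means faster removal of the compound, a lower number slower removal:
- compound 1 `CC(C(=O)O)c1nn(Cc2cn3cc(OCC4CC4)c(Cl)cc3n2)c2ccccc2c1=O`: 35 mL/min/kg
- compound 2 `CC(C)(C(=O)O)c1nn(Cc2cn3cc(OCC4CC4)c(Cl)cc3n2)c2ccccc2c1=O`: 21.7 mL/min/kg

Compound 1 has one measured neighbour, and the two values lie within the scatter of each other. Compound 3 `CC(C(=O)O)c1nn(Cc2cn3cc(OCC4CC4)c(C(F)(F)F)cc3n2)c2ccccc2c1=O` has trifluoromethyl in place of chloro on an aromatic carbon. Going by the values given here, the only measured step is a 1.6-fold lower number from compound 1 to compound 2 (0.21 log units; within the scatter). It is a change on the saturated chain, so it says nothing directly about this swap, and the data hold no measured change at the aromatic carbon. No shift beyond the scatter is therefore expected in this assay, and the estimated step is a 1.1-fold lower number from compound 1 to compound 3 (0.04 log units; within the scatter). Compound 3 is expected at 32 mL/min/kg, with an estimated range of 15 mL/min/kg to 65 mL/min/kg.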

Compound 3, clearance: 18.3 mL/min/kg
Estimate against measurement, compound 3: 1.7-fold (0.24 log units) above; the measured number falls inside the stated range.
By their numbers in this assay, from the lowest: compounds 3, 2 and 1 (each within the scatter of the next).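

In this assay, going by these compounds alone, trifluoromethyl in place of chloro gives a 1.9-fold lower number from compound 1 to compound 3 (0.28 log units; within the scatter) and is the first measured change on this aromatic carbon, ortho to the cyclopropylmethoxy group. At this position, then, the larger group leaves clearance within repeat-measurement scatter of the chloro compound. Nothing available bears on the reason for this result.

Still open, on these data alone, is whether a nitrile, a methoxy or an amine on this carbon would move clearance beyond the scatter. Also open, as far as these compounds go, is whether trifluoromethyl gives a similar step when combined with the extra methyl of compound 2.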